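The source may hold more compounds than are shown below. What is called first, only, known or untested is meant among the compounds shown, and "the series" means these compounds.

Measured in a functional assay on Caco-2 cells (Homo sapiens) for inhibition, read by MTT assay, with a stated time of 48 h, tested at 10 uM; on this read-out lower numbers stand for less inhibition of growth and higher numbers for more inhibition of growth at the one concentration tested:
Compound 1 `Cc1cc(=O)c2c(O)c(CN3CCCC3)c(O)c([C@H]3CCN(C)C[C@H]3O)c2o1`: 22%
Compound 2 `CCOC(=O)N1CCN(Cc2c(O)c([C@H]3CCN(C)C[C@H]3O)c3oc(C)cc(=O)c3c2O)CC1`: 18%
Compound 3 `Cc1cc(=O)c2c(O)c(CN3CC(O)CC3C(=O)O)c(O)c([C@H]3CCN(C)C[C@H]3O)c2o1`: 19%

Compound 3 lies within the scatter of both compound 1 and compound 2. Compound 4 `Cc1cc(=O)c2c(O)c(CN3CCCC3C(=O)O)c(O)c([C@H]3CCN(C)C[C@H]3O)c2o1` differs from compound 3 by hydrogen in place of hydroxy on a saturated ring carbon. For the measured compounds named here, no measured step isolates this change. The three measured steps exchange the whole group on the saturated chain carbon, and all stay small: a number 4 percentage points lower from compound 1 to compound 2 (within the scatter), a number 3 percentage points lower from compound 1 to compound 3 (within the scatter) and a number 1 percentage points higher from compound 2 to compound 3 (within the scatter). No shift beyond the scatter is therefore expected in this assay. The expected step is no change at the digits printed from compound 3 to compound 4 (within the scatter). The estimate for compound 4 is 19%, with an expected range from 10% to 29%.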

Compound 4, percent growth inhibition at one concentration: 30%
Compound 4: the middle estimate sits 11 percentage points below what was measured; measured number above the stated range.
By their numbers in this assay, from the lowest: compounds 2, 3, 1 and 4 (each within the scatter of the next, the first and the last beyond it).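

In this assay, for the compounds shown here, hydrogen in place of hydroxy on this saturated ring carbon gives a number 11 percentage points higher from compound 3 to compound 4 (beyond the scatter) and so yields a shift beyond the scatter, which no exchange among the earlier compounds had done. Compound 4 also stands apart from the piperazine compound, with a number 12 percentage points higher from compound 2 to compound 4 (beyond the scatter), while carboxy in place of hydrogen on the pyrrolidine gives only a number 8 percentage points higher from compound 1 to compound 4 (within the scatter). Nothing available explains the effect of removing this hydroxy. As far as these compounds go, whether a methoxy group, a fluorine or an amine on this ring carbon would match hydrogen or hydroxy remains open.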